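This account rests on a few compounds, and the source may have more. Where it says the series, first, only, none or still open, it means among the compounds named here.

Of the compounds shown here, three have so far been measured in an in vitro functional assay on 1321-N1 cells for antagonist activity at transient receptor potential cation channel subfamily V member 1 (Homo sapiens), read by FLIPR and calcium flux; a higher number here means a more potent compound, by a factor of ten per unit of this negative logarithm, a lower number a less potent compound. Compound 2 `Cc1nc2ccc(NC(=O)c3ccc(-c4ccc(F)cc4)nc3C)cc2[nH]1` gives 6 in this assay. Compound 3 `Cc1nc(-c2ccc(F)cc2)ccc1C(=O)Nc1ccc2scnc2c1` gives 7.5 in this assay. Compound 1 `N#Cc1ccc(-c2ccc(C(=O)Nc3ccc4cccnc4c3)cn2)cc1` stands apart from these two: in this assay compound 1 returns only a limit, < 6.6, and not a number. The evidence the limit of < 6.6 in this assay, at which 1 of the 3 values shown sits, records that a single one of the three values sits at this limit.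

Compound 4 `O=C(Nc1ccc2cccnc2c1)c1ccc(-c2ccccc2F)nc1` has not yet been measured. It differs from compound 1 in one place: 2-fluorophenyl in place of 4-cyanophenyl on an aromatic carbon next to the ring nitrogen. Going by the values given here, no measured pair of compounds differs in this single way, so the size of this step cannot be read from the numbers at hand. Compound 2 and compound 3 each carry a fluorophenyl group on their cores, but both differ from compound 4 in other places as well, so their values only frame what such a group may bring.

The step from compound 1 to compound 4 is expected to be a rise, a number at least 0.20 log units higher from compound 1 to compound 4 (that floor lies within the scatter), beyond the usual scatter. Compound 4 is therefore estimated at 6.8, with a likely range from 5.8 to 7.8.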

Compound 4, negative logarithm of the antagonist equilibrium constant: 8.7
Estimate against measurement, compound 4: 1.90 log units below; the measured number lies above the stated range.
By their numbers in this assay, from the lowest: compound 2; then compound 3; then compound 4.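

Putting 2-fluorophenyl in place of 4-cyanophenyl on an aromatic carbon next to the ring nitrogen, with the rest of the core of compound 1 unchanged, gives a number at least 2.10 log units higher from compound 1 to compound 4 (beyond the scatter) in this assay. This is the first change in one place that can be read among these compounds, and it shows that the group held at this position can move the read-out far beyond the scatter on this core, which compound 2 and compound 3, differing in other places as well, could only frame. Compound 1 returns a limit and not a number, so the step is a floor and its full size stays unknown: the limit of < 6.6 in this assay, at which 1 of the 4 values shown sits.

The compounds shown do not tell whether the rise comes from losing the 4-cyanophenyl group or from gaining the 2-fluorophenyl group, and a plain phenyl or a 2-methoxyphenyl at this position would help to separate the two. On these data alone, whether a step of this size would carry over to the cores of compound 2 and compound 3 also remains open.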